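Acetyl for methyl on the ether oxygen of compound 3

The compounds below may be only part of what the source reports. "The series", "measured", "known", "first", "only" and "open" are said of these compounds alone.

Compound 3 `CCOc1c(-c2occ(C)c2COC)ccc2c(CC)cccc12` has been run in a functional assay on SK-BR-3 cells (Homo sapiens) for cytotoxicity, read by MTT assay, with a stated time of 72 h; on this read-out higher numbers stand for an effect only at larger amounts of compound and lower numbers for an effect already at smaller amounts. In this assay compound 3 gives > 10 ug/mL, a limit of the assay and not a number. Compound 1 `CCOc1c(-c2occ(C)c2C(=O)O)ccc2c(CC)cccc12` also sits at the limit > 10 ug/mL in this assay. Compound 2 `CCc1cccc2c(OC(C)=O)c(-c3occ(C)c3COC(C)=O)ccc12` sits at the limit > 10 ug/mL in this assay. All three values rest on (the limit of > 10 ug/mL in this assay, at which 3 of the 3 values shown sit). Going by the values given here, the single one-site step among them, a step that the two limits leave unreadable from compound 1 to compound 3, is therefore not readable in size. Compound 4 `CCOc1c(-c2occ(C)c2COC(C)=O)ccc2c(CC)cccc12` differs from compound 3 by acetyl in place of methyl on an oxygen on a saturated carbon. Among the compounds with values here, no measured step bears on this change; compound 2 carries the same acetoxymethyl group and also stands at the limit. The step that the limit leaves unreadable from compound 3 to compound 4 is therefore expected to leave compound 4 at the limit as well. Compound 4 is estimated at 20 ug/mL, with a range from 8 ug/mL to 60 ug/mL.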

Compound 4, concentration for half-maximal effect: > 10 ug/mL
Compound 4: only a limit was reported; the forecaster's own chance of this, stated with the estimate: 80%; the middle value is on the limit's open side.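

In this assay compound 4 gives > 10 ug/mL as a limit of the assay and not a number, so its steps from compound 1, compound 2 and compound 3 cannot be read: the limit of > 10 ug/mL in this assay, at which 4 of the 4 values shown sit. In this assay the compounds shown leave open whether any of these changes shifts cytotoxicity at all.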